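The compounds below may be only part of what the source reports. "The series", "measured", "known", "first", "only" and "open" are said of these compounds alone.

Measured so far in a functional assay on PC-3 cells (Homo sapiens) for cytotoxicity, read by MTT assay, with a stated time of 72 h (on this read-out lower numbers stand for stronger inhibition and higher numbers for weaker inhibition), are three compounds:

Compound 1 `O=C(N/N=C/c1cccc(Br)c1)Nc1cc2c(Nc3ccc(F)c(Cl)c3)ncnc2cc1O[C@H]1CCOC1` gives 15500 nM
Compound 2 `O=C(N/N=C/c1ccc(F)cc1Cl)Nc1cc2c(Nc3ccc(F)c(Cl)c3)ncnc2cc1O[C@H]1CCOC1` gives 28400 nM
Compound 3 `O=C(N/N=C/c1cccc(Cl)c1Cl)Nc1cc2c(Nc3ccc(F)c(Cl)c3)ncnc2cc1O[C@H]1CCOC1` gives 27400 nM

These three differ only in the aryl group on a carbon with a double bond to nitrogen. Compound 3 at 27400 nM cannot be told apart from the other two. The measured gaps are a 1.0-fold lower number from compound 2 to compound 3 (0.02 log units; within the scatter) and a 1.8-fold higher number from compound 1 to compound 3 (0.25 log units; within the scatter) in this set.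

Compound 4 `COc1ccc(/C=N/NC(=O)Nc2cc3c(Nc4ccc(F)c(Cl)c4)ncnc3cc2O[C@H]2CCOC2)cc1` changes the same place, with 4-methoxyphenyl in place of 2,3-dichlorophenyl on a carbon with a double bond to nitrogen is the full count. Among the compounds with values here, no measured compound carries this entering group, so the data offer only indirect guidance. The remaining step, a 1.8-fold higher number from compound 1 to compound 2 (0.26 log units; within the scatter) as well, stayed small, so no step beyond the scatter is expected in this assay here. The expected step is a 1.2-fold lower number from compound 3 to compound 4 (0.10 log units; within the scatter) as an estimate. Compound 4 is estimated at 22000 nM with an expected range from 10000 nM to 46000 nM in this measurement.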

Compound 4, half-maximal inhibitory concentration: 34100 nM
Estimate against measurement, compound 4: 1.6-fold (0.19 log units) below; measured number inside the range.
By their numbers in this assay, from the lowest: compounds 1, 3, 2 and 4 (each within the scatter of the next, the first and the last beyond it).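

In this assay, within the data shown here, 4-methoxyphenyl is the first group at this position that carries oxygen and no halogen, yet the number stays within the scatter of two chlorine-bearing compounds, with a 1.2-fold higher number from compound 3 to compound 4 (0.10 log units; within the scatter) and a 1.2-fold higher number from compound 2 to compound 4 (0.08 log units; within the scatter). Against 3-bromophenyl the picture differs: a 2.2-fold higher number from compound 1 to compound 4 (0.34 log units; beyond the scatter) is the first step in this set to pass the scatter, though only modestly. So the aryl group on a carbon with a double bond to nitrogen can shift the number measurably, but across these four groups the shift remains small.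

No measurement is available here to explain these differences. On these data alone, it remains open whether an aryl group carrying an amine or a carboxylic acid, or a longer chain in place of the aryl ring, would move the number further in either direction.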